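The compounds below may be only part of what the source reports. "The series", "measured", "known", "first", "only" and "open" are said of these compounds alone.

The measured compounds and their readings in an assay on CHO cells for displacement of a labelled ligand from adenosine receptor A1 (Homo sapiens), read by scintillation counting, tested at 10 uM; on this read-out lower numbers stand for less inhibition and higher numbers for more inhibition at the one concentration tested (going by the name of the read-out):
compound 1, `CC(C)(C)c1csc(N)c1C(=O)c1ccc(Cl)cc1`, 1%
compound 2, `CC(C)(C)Cc1c(-c2cccc(F)c2F)sc(N)c1C(=O)c1ccc(Cl)cc1`, 1%
compound 3, `COc1ccc(-c2sc(N)c(C(=O)c3cccc(C(F)(F)F)c3)c2CC(C)(C)C)cc1`, 2%

Compound 2 stands level with compound 1 at the digits given, and together the two hold the lowest of the three numbers. Its nearest neighbour is compound 1, with no change at the digits given, which lies within the scatter. Its furthest neighbour is compound 3, and that gap too lies within the scatter, so the three readings in this assay cannot be told apart.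

The next compound, compound 4, `CC(C)(C)Cc1c(-c2cn[nH]c2)sc(N)c1C(=O)c1ccc(Cl)cc1`, has not yet been measured in this assay. It differs from compound 2 in one place: 1H-pyrazol-4-yl in place of 2,3-difluorophenyl on an aromatic carbon. Going by the values given here, no pair among the measured compounds shows a change of this kind, so nothing measured speaks to its effect; the record only shows that every variation tried so far, on the ring carbon in question and elsewhere, has left the reading in this assay where it began.

On that basis the step of a number 1 percentage points higher from compound 2 to compound 4 (within the scatter) is expected to be none beyond the scatter, with no direction to it. Compound 4 is therefore estimated to give 2% in this assay, with a range from -6% to 14%, because compound 2 gives 1% and its neighbours sit with it.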

Compound 4, a percentage reported as inhibition, at one concentration (the size of the read-out at that concentration, not a potency): 1%
For compound 4 the middle estimate is 1 percentage points above the measured one; low and high end bracket the measured number.
By their numbers in this assay, from the lowest: compounds 1, 2, 4 and 3 (each within the scatter of the next).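

In this assay, going by these compounds alone, putting 1H-pyrazol-4-yl in place of 2,3-difluorophenyl on the aromatic carbon next to the ring sulfur gives no change at the digits printed from compound 2 to compound 4 (within the scatter) and supplies the first direct comparison at this position. The exchange is not a small one on paper: a five-membered aromatic ring with 2 hetero atoms, 1 hydrogen-bond donor and 1 hydrogen-bond acceptor replaces a six-membered aromatic ring of carbon only with 0 of either, yet the reading in this assay stays level, so these two groups cannot be told apart here. Nothing measured in this set accounts for that flat result.

Open, as far as these compounds go, is whether a carboxylic acid, a morpholine or a longer alkyl chain on this carbon would carry the reading in this assay clear of the scatter, since both groups compared here leave it at the same low level. Equally open, from the compounds shown here alone, is whether 1H-pyrazol-4-yl would behave the same way with a smaller group than neopentyl on the neighbouring ring atom, or with an acetyl group on the amino group.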